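The compounds below may be only part of what the source reports. "The series", "measured", "known", "first", "only" and "open" are said of these compounds alone.

Measured so far in a functional assay on the whole organism (Tail, strain ICR) with Mus musculus as the target, in the tail flick test, with a stated time of 120 min, at a dose of 25 umol/kg by the oral route; a lower number here means a weaker effect, a higher number a stronger effect of the compound at the dose given:
- compound 1 `C[C@H](NC(=O)CN(c1nc(Cl)nc2[nH]cnc12)C1CC1)C(=O)OCc1ccccc1` gives 36.1%
- compound 2 `O=C(CN(c1ncnc2c1ncn2C1CCCCO1)C1CC1)N[C@@H](CC(=O)OCc1ccccc1)C(=O)OCc1ccccc1` gives 7.82%

Compound 2 stands lowest of the two numbers; its nearest neighbour, compound 1, lies higher by a margin beyond the scatter. Compound 3 `CC(C)[C@H](NC(=O)CN(c1ncnc2c1ncn2C1CCCCO1)C1CC1)C(=O)OCc1ccccc1` is not yet measured. From compound 2 it differs in one place: isopropyl in place of (benzyloxycarbonyl)methyl on a saturated chain carbon bound to an amide-type nitrogen and a carbonyl carbon. For the measured compounds named here, no step between measured compounds covers this change, and compound 1 differs from compound 2 in more than this one place, so its number gives only loose guidance. The step is expected to go upward, moderately, as a number 14.2 percentage points higher from compound 2 to compound 3 (beyond the scatter). Compound 3 is estimated at 22%, within 8% to 38%.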

Compound 3, a percentage reported as activity, at one dose (the size of the read-out at that dose, not a potency): 25.8%
The estimate for compound 3 lay 3.8 percentage points below the measured number; the measured number falls inside the stated range.
By their numbers in this assay, from the lowest: compound 2; then compound 3; then compound 1.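

In this assay the position on the saturated chain carbon bound to an amide-type nitrogen and a carbonyl carbon now has a first reading, with isopropyl in place of (benzyloxycarbonyl)methyl giving a number 18 percentage points higher from compound 2 to compound 3 (beyond the scatter) at this dose. The group that leaves carries a six-membered aromatic ring of carbon only, while the group that enters has no ring. Nothing at hand gives a reason for the step.

Open, as far as these compounds go, is whether a longer alkyl chain, a benzyl group or a free carboxylic acid at this carbon would hold the read-out. From the compounds shown here alone, whether ring or size governs the step also stays open.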